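The source may report more compounds than this note shows. Statements on the series, on what has been measured and on what is new or still open speak of the compounds shown alone.

compound 1 `CC(C)(C)c1ccc(OCCCON2C(N)=NC(N)=NC23CCSCC3)cc1`: 1 nM
compound 2 `COc1ccc(OCCCON2C(N)=NC(N)=NC23CCOCC3)cc1`: "not determined" (no result reported)

Among the compounds with values here, in a functional assay on MDA-MB-231 cells (Homo sapiens) for antiproliferative activity, read by MTT assay, with a stated time of 72 h (on this read-out lower numbers stand for stronger inhibition and higher numbers for weaker inhibition), compound 1 gives 1 nM as the only number available, so it cannot be ranked against anything. For compound 2 the entry reads "not determined" (no result reported) and offers no comparison. Compound 3 `NC1=NC2(CCSCC2)N(OCCCOc2ccc(Br)cc2)C(N)=N1` keeps the core of compound 1 and alters one group: bromo in place of tert-butyl on an aromatic carbon in short, bromo in place of tert-butyl on an aromatic carbon. Within the data shown here, no measured pair shows this swap, so the data give no size for it. With compound 1 at 1 nM already so low, a single replacement seems more likely to lose than to gain, so weaker inhibition is the expected direction. The expected step is a 5.0-fold higher number from compound 1 to compound 3 (0.70 log units; beyond the scatter) by this estimate, probably beyond the usual scatter. Compound 3 is estimated at 5 nM with a range of 0.8 nM to 40 nM when tested.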

Compound 3, half-maximal inhibitory concentration: 440 nM
Compound 3: middle estimate off by 88-fold (1.94 log units), on the low side, outside the stated range (above it).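

Going from tert-butyl to bromo on this aromatic carbon moves the result in this assay by a large step, a 440-fold higher number from compound 1 to compound 3 (2.64 log units; beyond the scatter), so the activity of this series is highly sensitive to the group at this position. The swap replaces 4 heavy atoms, all carbon, with 1 bromine atom, while the counts of hydrogen-bond donors and acceptors and the net charge stay the same, so those counts do not separate the two groups. No measured evidence here explains why the number rises so far.

A single pair cannot show whether the rise follows the number of heavy atoms or the switch from carbon to bromine. Methyl, isopropyl or chlorine in this place would be needed to pull those two apart, and the data shown include none of them.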